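The compounds below may be only part of what the source reports. "The series", "measured", "known", "first", "only" and "open" are said of these compounds alone.

Among the compounds with values here, compound 1 `CCCC(Oc1ccc(-n2cc(OC)cn2)cc1)c1ccc(C(=O)NCCC(=O)O)cc1` stands at the low end of the two compounds measured so far in a physicochemical assay for lipophilicity, using the shake flask method, at pH 7.4; on this read-out lower numbers stand for lower lipophilicity and higher numbers for higher lipophilicity. Compound 1 gives 1.4, while compound 2 `CC(C)(C)C(Oc1ccc(-n2cc(C(F)(F)F)cn2)cc1)c1ccc(C(=O)NCCC(=O)O)cc1` gives 3.7, a gap well beyond the scatter. These two compounds differ in more than one place, so their gap cannot be read as the size of any single change. The unmeasured compound 3 `CCCC(Oc1ccc(-n2cc(F)cn2)cc1)c1ccc(C(=O)NCCC(=O)O)cc1` departs from compound 1 in one place only, fluoro in place of methoxy on an aromatic carbon, turning 4-methoxy-1H-pyrazol-1-yl into 4-fluoro-1H-pyrazol-1-yl. Within the data shown here, no measured pair shows this exchange, so the expectation rests on the structural change alone and remains modest. A small step upward is expected, not clearly beyond the scatter. The expected size of this move is a number 0.20 log units higher from compound 1 to compound 3 (within the scatter). In this assay, the estimated value for compound 3 is 1.6, with an expected range from 1.2 to 2.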

Compound 3, distribution coefficient: 2
For compound 3 the middle estimate is 0.40 log units below the measured one, within the range that was stated.
By their numbers in this assay, from the lowest: compound 1; then compound 3; then compound 2.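

In this assay, fluoro in place of methoxy on an aromatic carbon of the five-membered aromatic ring gives a number 0.60 log units higher from compound 1 to compound 3 (beyond the scatter), which shows that this one position alone can move the read-out by more than the usual scatter. Compound 1 and compound 2 differ in more than one place, so this is the only step shown whose size belongs to a single change. The exchange takes away methoxy, with its two heavy atoms and one hydrogen-bond acceptor, and puts in fluoro, with one heavy atom and no hydrogen-bond acceptor, but nothing available explains why the number rises with this change.

The compounds shown leave open how a nitrile, a chloro or a methyl group on this same carbon would compare with fluoro and methoxy, and the trifluoromethyl group of compound 2 cannot settle this, as compound 2 also differs elsewhere. From the compounds shown here alone, whether the exchange of methoxy for fluoro would give a step of similar size in the setting of compound 2 also remains open.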